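The compounds below may be only part of what the source reports. "The series", "measured", "known", "first", "only" and "open" are said of these compounds alone.

Compound 2 `C/C(=C\C(=O)Nc1ccccc1OCCCC(=O)O)c1ccc2c(ccn2Cc2cccc(C)c2)c1` carries a 3-methylbenzyl on the aromatic nitrogen of the shared core. Going by the values given here, in an assay on Prostate gland for inhibition of steroid 5-alpha-reductase (Rattus norvegicus) (on this read-out higher numbers stand for weaker inhibition and lower numbers for stronger inhibition), compound 2 gives 250 nM, the highest of the two numbers so far. Among the compounds with values here, its only measured neighbour is compound 1 `CCCC(C)n1ccc2cc(/C(C)=C/C(=O)Nc3ccccc3OCCCC(=O)O)ccc21`, which in this assay gives 7.8 nM; the step of a 32-fold higher number from compound 1 to compound 2 (1.51 log units; beyond the scatter) is the one measured change at this nitrogen, a large loss of inhibition when 3-methylbenzyl replaces 1-methylbutyl.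

Compound 3 `CCCCC(c1ccccc1)n1ccc2cc(/C(C)=C/C(=O)Nc3ccccc3OCCCC(=O)O)ccc21` is not yet measured. It differs from compound 2 in one place: 1-phenylpentyl in place of 3-methylbenzyl on an aromatic nitrogen. The entering 1-phenylpentyl is a branched chain on that nitrogen, as 1-methylbutyl is in compound 1, while the aromatic ring is kept. Within the data shown here, the only relevant measured step, from compound 1 to compound 2, points to the branched chain being the favourable arrangement, so a step back toward stronger inhibition is expected, though not necessarily all the way to the number of compound 1. Compound 3 is therefore estimated at 20 nM in this assay, within 5 nM to 80 nM, which means an expected step of a 13-fold lower number from compound 2 to compound 3 (1.10 log units; beyond the scatter).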

Compound 3, half-maximal inhibitory concentration: 9.8 nM
The estimate for compound 3 lay 2.0-fold (0.31 log units) above the measured number; the measured number falls inside the stated range.
By their numbers in this assay, from the lowest: compounds 1 and 3 (each within the scatter of the next); then compound 2.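

Replacing 3-methylbenzyl with 1-phenylpentyl on the aromatic nitrogen gives a 26-fold lower number from compound 2 to compound 3 (1.41 log units; beyond the scatter) in this assay, so the large loss seen at this position with compound 2 can be recovered with the aromatic ring still present. The change from 1-methylbutyl to 1-phenylpentyl gives a 1.3-fold higher number from compound 1 to compound 3 (0.10 log units; within the scatter) and so makes no readable difference, which shows that this position accepts a six-membered aromatic ring on a branched chain without a measurable penalty; among these three compounds, only compound 2, with its 3-methylbenzyl, stands apart. Nothing at hand gives a reason for either step.

The compounds shown do not separate the branch from the other features of the groups: a straight pentyl chain or an unsubstituted benzyl on the nitrogen would be needed to tell whether the branch itself, or the methyl on the ring of 3-methylbenzyl, goes with the higher number of compound 2. They also leave open how a 1-phenylpropyl group or a hydroxyl on the phenyl ring of 1-phenylpentyl would read in this assay at this position.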